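Chloro to fluoro on the aryl ring of compound 3

The source may hold more compounds than are shown below. What is called first, only, known or untested is meant among the compounds shown, and "the series" means these compounds.

Measured in a functional assay on PC-3 cells (Homo sapiens); a lower number here means a stronger inhibitor of growth, a higher number a weaker inhibitor of growth:
- Compound 1 `O=S(=O)(/C=C/c1ccc(Cl)cc1Cl)Cc1ccc(Nc2ncnc3cc(Cl)ccc23)cc1`: 38000 nM
- Compound 2 `O=S(=O)(/C=C/c1ccc(C(F)(F)F)cc1F)Cc1ccc(Nc2ncnc3cc(Cl)ccc23)cc1`: > 100000 nM, a limit of the assay
- Compound 3 `O=S(=O)(/C=C/c1ccc(F)cc1Cl)Cc1ccc(Nc2ncnc3cc(Cl)ccc23)cc1`: 73000 nM

Among the measured compounds shown here, compound 3 gives 73000 nM, within the scatter of compound 1, the only other compound with a number.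

Compound 4 `O=S(=O)(/C=C/c1ccc(F)cc1F)Cc1ccc(Nc2ncnc3cc(Cl)ccc23)cc1` is not yet measured. It differs from compound 3 by fluoro in place of chloro on an aromatic carbon, ortho to a large group and meta to a fluoro group.

The closest measured precedent is a 1.9-fold higher number from compound 1 to compound 3 (0.28 log units; within the scatter), also fluoro in place of chloro on an aromatic carbon. The exchange of 2,4-dichlorophenyl for 2-fluoro-4-(trifluoromethyl)phenyl, an at least 2.6-fold higher number from compound 1 to compound 2 (0.42 log units; beyond the scatter), is a larger change and bears less directly. In this assay, a small step to a higher number is therefore expected, possibly none beyond the scatter, and a report of a limit alone is a real possibility.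

The estimate corresponds to an expected 1.2-fold higher number from compound 3 to compound 4 (0.09 log units; within the scatter).

For compound 4, the estimated value is 90000 nM, with an expected range of 45000 nM to 180000 nM.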

Compound 4, concentration for 50% growth inhibition: > 100000 nM
Compound 4 was reported as a limit; the forecaster's own chance of this, stated with the estimate: 40%; middle value at least 1.1-fold (0.04 log units) from the limit.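

Compound 4 is reported in this assay only as a limit of the assay, and fluoro in place of chloro, ortho to a large group and meta to a fluoro group, gives an at least 1.3-fold higher number from compound 3 to compound 4 (0.13 log units; that floor lies within the scatter), so this step alone cannot be separated from the scatter. Read from the 2,4-dichlorophenyl group of compound 1, however, the change to 2,4-difluorophenyl gives an at least 2.6-fold higher number from compound 1 to compound 4 (0.42 log units; beyond the scatter), whereas the single exchange, a 1.9-fold higher number from compound 1 to compound 3 (0.28 log units; within the scatter), stays within the scatter. The step between compound 2 and compound 4 cannot be read, and the true size of the other steps to a limit stays unresolved: the limit of > 100000 nM in this assay, at which 2 of the 4 values shown sit.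

As far as these compounds go, how far compound 4 lies from compound 3 remains open. Also open, from the compounds shown here alone, is what a bromo, a methoxy or an amine at this position would give in this assay.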